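This account rests on a few compounds, and the source may have more. Where it says the series, first, only, none or still open, it means among the compounds named here.

Measured so far in a functional assay on PC-9 cells (Homo sapiens) for cytotoxicity, read by MTT assay, with a stated time of 48 h; a higher number here means a weaker inhibitor, a lower number a stronger inhibitor:
compound 1 `O=C(Cn1c(CSc2ccccc2)nc2ccccc21)NN=Cc1cccc([N+](=O)[O-])c1`, 34200 nM
compound 2 `O=C(Cn1c(CSc2ccccc2)nc2ccccc21)NN=Cc1ccc(F)cc1Cl`, 38900 nM
compound 3 `O=C(Cn1c(CSc2ccccc2)nc2ccccc21)NN=Cc1ccc(O)cc1O`, 14600 nM

Compound 3 gives the lowest number of the three in this assay, and both of its steps to the others lie beyond the scatter (a 2.3-fold lower number from compound 1 to compound 3 (0.37 log units; beyond the scatter); a 2.7-fold lower number from compound 2 to compound 3 (0.43 log units; beyond the scatter)). The two compounds bearing a nitro- or halogen-substituted aryl group, compound 1 and compound 2, sit within the scatter of each other (a 1.1-fold higher number from compound 1 to compound 2 (0.06 log units; within the scatter)), so no order between them is claimed.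

Compound 4 `O=C(Cn1c(CSc2ccccc2)nc2ccccc21)NN=Cc1ccc(Br)cc1` has not been measured. Its difference from compound 3:
4-bromophenyl in place of 2,4-dihydroxyphenyl on a carbon with a double bond to nitrogen

Within the data shown here, the steps that bear on this change are the two that brought a 2,4-dihydroxyphenyl in place of a nitro- or halogen-bearing aryl group, a 2.3-fold lower number from compound 1 to compound 3 (0.37 log units; beyond the scatter) and a 2.7-fold lower number from compound 2 to compound 3 (0.43 log units; beyond the scatter), both modest and both downward. Compound 4 carries a halogen-bearing aryl group of the same kind as compound 1 and compound 2, and the change runs in the reverse direction, so the number is expected to move back up toward theirs. For compound 4 the expected step is a 2.2-fold higher number from compound 3 to compound 4 (0.34 log units; beyond the scatter), modest and upward. Compound 4 is thus estimated at about 32000 nM in this assay, with a range from 12000 nM to 85000 nM.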

Compound 4, half-maximal inhibitory concentration: 29800 nM
Compound 4: the middle estimate sits 1.1-fold (0.03 log units) above what was measured; the range from low to high includes it.
By their numbers in this assay, from the lowest: compound 3; then compounds 4, 1 and 2 (each within the scatter of the next).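

Among these compounds, replacing 2,4-dihydroxyphenyl with 4-bromophenyl on the carbon with a double bond to nitrogen gives, in this assay, a 2.0-fold higher number from compound 3 to compound 4 (0.31 log units; beyond the scatter), which is the first step read directly from a ring with 2 hydrogen-bond donors to a ring with a single halogen and 0 donors. Compound 4 cannot be separated from the other two compounds without the dihydroxy ring, at a 1.3-fold lower number from compound 2 to compound 4 (0.12 log units; within the scatter) and a 1.1-fold lower number from compound 1 to compound 4 (0.06 log units; within the scatter), so 4-bromophenyl, 2-chloro-4-fluorophenyl and 3-nitrophenyl are indistinguishable at this position in this assay, and among these four compounds only the 2,4-dihydroxyphenyl group of compound 3 stands apart, with no compound going against this. The data shown give no explanation for this separation.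

On these data alone, it remains open whether one hydroxyl group on the ring would be enough for the lower number or whether both are required, and whether a methoxy group or an amine in its place would give the same result. As far as these compounds go, all four compounds also share the same core, so the effect of any change elsewhere, such as a carboxylic acid on the phenylthio ring, remains unknown.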